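A few compounds are considered here, and "the series" means these few. Any claim that something is new, unique, unknown or untested is made for them only; others in the source may bear on it.

Three measured compounds share one core; in a functional assay on HeLa cells (Homo sapiens) for cytotoxicity, read by MTT assay, with a stated time of 72 h (on this read-out higher numbers stand for weaker inhibition and lower numbers for stronger inhibition), compound 1 `Cc1ccc(CSc2cc(Cl)c(C)cc2S(=O)(=O)/N=C(\N)n2nc(C)cc2-c2ccccc2)cc1` gives 62000 nM, compound 2 `Cc1cc(-c2ccccc2)n(/C(N)=N/S(=O)(=O)c2cc(C)c(Cl)cc2SCc2ccccc2C)n1` gives 160000 nM, and compound 3 `Cc1cc(S(=O)(=O)/N=C(\N)n2nccc2-c2ccccc2)c(SCc2ccccc2C)cc1Cl` gives 17000 nM. Compound 3 thus stands lowest of the three numbers, beyond the scatter from both others; the two steps between them read a 2.6-fold higher number from compound 1 to compound 2 (0.41 log units; beyond the scatter) and a 9.4-fold lower number from compound 2 to compound 3 (0.97 log units; beyond the scatter). Compound 4 `Cc1cc(S(=O)(=O)/N=C(\N)n2nccc2-c2ccccc2)c(SCc2ccc(Cl)cc2)cc1Cl` differs from compound 3 in one place: 4-chlorophenyl in place of 2-methylphenyl on a saturated chain carbon bound to a sulfur. Of the measured steps only the first touches this group, where shifting the methyl on the ring gave a 2.6-fold higher number from compound 1 to compound 2 (0.41 log units; beyond the scatter); a chlorine on that ring has not been measured in this assay. A modest step is therefore expected, leaning toward a lower number, estimated as a 1.4-fold lower number from compound 3 to compound 4 (0.15 log units; within the scatter). Compound 4 is estimated at 12000 nM, range 4000 nM to 40000 nM.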

Compound 4, half-maximal inhibitory concentration: 3000 nM
Compound 4: the middle estimate sits 4.0-fold (0.60 log units) above what was measured; measured number outside the range, below it.
By their numbers in this assay, from the lowest: compound 4; then compound 3; then compound 1; then compound 2.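

In this assay, the group on the saturated chain carbon bound to a sulfur can move the number down as well as up: 4-chlorophenyl in place of 2-methylphenyl gives a 5.7-fold lower number from compound 3 to compound 4 (0.75 log units; beyond the scatter), beyond the scatter. Going by these compounds alone, the one earlier step at this position, between two methylphenyl groups, went upward, and no chlorine on this ring had been read before. Nothing at hand explains this step.

Still open, from the compounds shown here alone, is whether the step belongs to the chlorine itself or to where it sits on the ring. Also open, going by these compounds, is how 4-trifluoromethylphenyl, 4-methoxyphenyl or a longer chain would read on the core of compound 4.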